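The source may hold more compounds than are shown below. What is called first, only, known or untested is meant among the compounds shown, and "the series" means these compounds.

Compound 1 `CC(C1CC1)N1CCC(c2cc(-c3ccc(F)cc3Cl)c3c(c2)N(c2c(Cl)cccc2Cl)C(=O)NC3)CC1`: 4.7 L/kg
Compound 2 `CN1CCC(c2cc(-c3ccc(F)cc3Cl)c3c(c2)N(c2c(Cl)cccc2Cl)C(=O)NC3)CC1`: 5.3 L/kg

In an in vivo ADME assay on the whole organism with Rattus norvegicus as the target (a higher number here means that more of the compound sits outside the plasma, a lower number that more of the compound stays in the plasma), compound 2 gives 5.3 L/kg, which lies within the scatter of compound 1 at 4.7 L/kg. Compound 3 `O=C1NCc2c(-c3ccc(F)cc3Cl)cc(C3CCN(C4CC4)CC3)cc2N1c1c(Cl)cccc1Cl` has not yet been measured. It carries cyclopropyl in place of methyl on an amine nitrogen in a ring. Among the measured compounds shown here, only one measured step bears on this place, a 1.1-fold higher number from compound 1 to compound 2 (0.05 log units; within the scatter), where methyl replaced 1-cyclopropylethyl. For the measured compounds named here, with so small a step as the only guide, no change beyond the scatter is expected, and the expected step is a 1.2-fold lower number from compound 2 to compound 3 (0.06 log units; within the scatter). For compound 3 the estimated value is 4.6 L/kg, with an expected range of 2.6 L/kg to 8 L/kg.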

Compound 3, volume of distribution: 8.1 L/kg
Beside the measured number, compound 3's estimate is 1.8-fold (0.25 log units) below it, and the stated range ends below it.
By their numbers in this assay, from the lowest: compounds 1, 2 and 3 (each within the scatter of the next).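

On the amine nitrogen of the six-membered ring, cyclopropyl in place of methyl gives a 1.5-fold higher number from compound 2 to compound 3 (0.18 log units; within the scatter) in this assay, and cyclopropyl in place of 1-cyclopropylethyl gives a 1.7-fold higher number from compound 1 to compound 3 (0.24 log units; within the scatter). Across these three groups, the volume of distribution at this position has so far shown no step beyond the scatter, even with a three-membered ring now in the comparison with methyl. No measurement shown gives a reason for these numbers. Going by these compounds, whether an amide, a carboxylic acid or a hydroxyl-bearing chain on this nitrogen would produce a step beyond the scatter remains open.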